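From furan-2-yl to 1H-pyrrol-2-yl on compound 3

A few compounds are considered here, and "the series" means these few. Any claim that something is new, unique, unknown or untested is made for them only; others in the source may bear on it.

In a functional assay on HCT-116 cells (Homo sapiens) for antiproliferative activity, read by resazurin assay, with a stated time of 5 days (a lower number here means a stronger inhibitor, a higher number a weaker inhibitor), compound 3 (`O=C(NCc1ccc2cc(C(=O)NO)sc2c1F)c1ccco1`) gives 90 nM and compound 2 (`Cc1ccc(C(=O)NCc2ccc3cc(C(=O)NO)sc3c2F)s1`) gives 120 nM, so the two sit level within the scatter. Compound 1 (`O=C(NO)c1cc2ccc(CN3CCc4ccccc4C3)c(F)c2s1`) gives 3000 nM, far from that pair.

Compound 4 (`O=C(NCc1ccc2cc(C(=O)NO)sc2c1F)c1ccc[nH]1`) is not yet measured and differs from compound 3 in one place: 1H-pyrrol-2-yl in place of furan-2-yl on a carbonyl carbon. This puts 1H-pyrrol-2-yl in place of furan-2-yl on a carbonyl carbon.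

Among the compounds with values here, only one measured step bears on this place: a 1.3-fold lower number from compound 2 to compound 3 (0.12 log units; within the scatter), with furan-2-yl in place of 5-methylthiophen-2-yl. That step lies within the scatter. Within the data shown here, it is a single step, and no measured compound carries the 1H-pyrrol-2-yl group, so the evidence is thin. No step beyond the scatter is therefore expected in this assay, in either direction.

The expected change is a 1.1-fold higher number from compound 3 to compound 4 (0.05 log units; within the scatter). Compound 4 is estimated at 100 nM, with an expected range of 40 nM to 250 nM.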

Compound 4, half-maximal inhibitory concentration: 300 nM
The estimate for compound 4 lay 3.0-fold (0.48 log units) below the measured number, outside the stated range (above it).
By their numbers in this assay, from the lowest: compounds 3 and 2 (each within the scatter of the next); then compound 4; then compound 1.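

In this assay, the group on a carbonyl carbon whose other neighbour is an amide-type nitrogen now proves able to move the number: a 3.3-fold higher number from compound 3 to compound 4 (0.52 log units; beyond the scatter) and a 2.5-fold higher number from compound 2 to compound 4 (0.40 log units; beyond the scatter), both beyond the scatter, whereas a 1.3-fold lower number from compound 2 to compound 3 (0.12 log units; within the scatter) stayed within it. Furan-2-yl and 1H-pyrrol-2-yl are both five-membered aromatic rings of 5 heavy atoms, so this step separates two groups that differ in their hetero atom, oxygen or nitrogen, and in their counts of hydrogen-bond donors and acceptors. Nothing measured here explains why the number rises with 1H-pyrrol-2-yl.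

As far as these compounds go, it remains open whether the hydrogen on the pyrrole nitrogen matters, which a 1-methyl-1H-pyrrol-2-yl group would test. Also unresolved is how a ring carrying an amine or a carboxylic acid would read at this place.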